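Dithiocarbamate benzamide series: pyrrolidinyl replacement

A few compounds are considered here, and "the series" means these few. Any claim that something is new, unique, unknown or untested is made for them only; others in the source may bear on it.

Measured so far:
compound 1, `CCN(Cc1ccncc1)C(=S)SCc1ccc(C(=O)Nc2ccccc2N)cc1`, 77.7%
compound 2, `Nc1ccccc1NC(=O)c1ccc(CSC(=S)N2CCN(c3cnccn3)CC2)cc1`, 76.9%

Both compounds share the same core and differ in the amine part of the dithiocarbamate. In a functional assay on HeLa cells (Homo sapiens) for antiproliferative activity, read by CCK-8 assay, with a stated time of 72 h, tested at 8 uM (a higher number here means a stronger effect of the compound at the concentration tested, a lower number a weaker effect), compound 1 gives 77.7%, and compound 2 gives 76.9%. The two values lie within the usual scatter of each other, so neither can be set above the other; compound 1 simply holds the larger of the two numbers.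

The next compound, compound 3, `Nc1ccccc1NC(=O)c1ccc(CSC(=S)N2CCCC2)cc1`, has not been measured. Compared with compound 1 the change is pyrrolidin-1-yl in place of ethyl((pyridin-4-yl)methyl)amino on a thiocarbonyl carbon. Going by the values given here, no step between measured compounds is known that would show what this kind of change does, so its size must be estimated from the two values alone, which are close and leave the direction open.

A modest lowering, roughly at the edge of the scatter, is expected for compound 3, giving an expected step of a number 9.7 percentage points lower from compound 1 to compound 3 (within the scatter). Compound 3 is expected to show 68%, with a range from 50% to 85%.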

Compound 3, a percentage reported as inhibition, at one concentration (the size of the read-out at that concentration, not a potency): 77.8%
Estimate against measurement, compound 3: 9.8 percentage points below, and the stated range covers the measured number.
By their numbers in this assay, from the lowest: compounds 2, 1 and 3 (each within the scatter of the next).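

In this assay, pyrrolidin-1-yl in place of ethyl((pyridin-4-yl)methyl)amino on a thiocarbonyl carbon gives a number 0.1 percentage points higher from compound 1 to compound 3 (within the scatter), so this change leaves no readable mark on the inhibition at the concentration tested. At this position, the read-out therefore holds when the group goes from 10 heavy atoms to 5 and the six-membered aromatic ring with its hydrogen-bond acceptor is lost, so neither the pyridine ring nor the ethyl chain is needed to keep the value in this pair. Nothing available on these compounds explains why the value holds.

A single-concentration read-out does not show whether compound 1 and compound 3 also match in potency, so a shared value here cannot be taken as equal potency. On these data alone, it also remains open how far this position tolerates change, for instance with a carboxylic acid on the pyrrolidine ring, a primary amine on a longer chain, or a plain dimethylamino group on the thiocarbonyl carbon.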